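The source may hold more compounds than are shown below. What is called first, only, known or untested is meant among the compounds shown, and "the series" means these compounds.

Compound 3 `COC(=O)[C@@]1(C)CCC=C2[C@@H]1CC[C@@H](C)[C@]2(C)Cc1c[nH]c2c(C)cccc12` stands, in a functional assay on T47D cells (Homo sapiens) for inhibition, read by sulforhodamine B assay, with a stated time of 48 h (on this read-out lower numbers stand for stronger inhibition of growth and higher numbers for weaker inhibition of growth), at the highest of the three measured numbers: compound 3 gives 18000 nM, while compound 1 `COC(=O)[C@@]1(C)CCC=C2[C@@H]1CC[C@@H](C)[C@]2(C)Cc1c[nH]c2ccc(F)cc12` gives 3900 nM and compound 2 `COC(=O)[C@@]1(C)CCC=C2[C@@H]1CC[C@@H](C)[C@]2(C)Cc1c[nH]c2ccc(OC)cc12` gives 3700 nM, and both of those gaps to compound 3 lie beyond the scatter. Compound 4 `COC(=O)[C@@]1(C)CCC=C2[C@@H]1CC[C@@H](C)[C@]2(C)Cc1c[nH]c2c(Cl)cccc12` differs from compound 3 by chloro in place of methyl on an aromatic carbon. Going by the values given here, the only measured step between compounds differing in one place, a 1.1-fold lower number from compound 1 to compound 2 (0.02 log units; within the scatter), concerns a different place on the same aromatic ring and a different pair of groups; it bears on the present step only in showing that one exchange of a substituent on that ring produced no movement in this assay. Among the compounds with values here, no measured step exchanges methyl for chloro anywhere, so the expectation rests on compound 3 alone and on the small size of the change. For compound 4 the step of no change at the digits printed from compound 3 to compound 4 (within the scatter) is expected, meaning none beyond the scatter. Compound 4 is therefore estimated at 18000 nM, with a range from 7000 nM to 45000 nM.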

Compound 4, concentration for 50% growth inhibition: 24000 nM
Estimate against measurement, compound 4: 1.3-fold (0.12 log units) below; the range from low to high includes it.
By their numbers in this assay, from the lowest: compounds 2 and 1 (each within the scatter of the next); then compounds 3 and 4 (each within the scatter of the next).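

In this assay, chloro in place of methyl on this aromatic carbon, ortho to a fused ring and meta to a fused ring, gives a 1.3-fold higher number from compound 3 to compound 4 (0.12 log units; within the scatter), so this position accepts either group without movement beyond the scatter. Going by these compounds alone, the earlier step exchanged fluoro and methoxy at a different place on the ring, so this is the first reading of a single exchange at this carbon. No measured evidence accounts for the result or bears on it.

Methyl and chloro are the only groups seen at this position, so the effect of an amine, a carboxylic acid or a longer chain there remains open. Also open, going by these compounds, is how the read-out responds to a change elsewhere, such as a carboxylic acid in place of the methyl ester on the shared core.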